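Terminal group variation at the chain end: compound 4

A few compounds are considered here, and "the series" means these few. Any claim that something is new, unique, unknown or untested is made for them only; others in the source may bear on it.

Compound 3 `CC/N=C(/NC#N)NCCCCCCn1nc(-c2ccccc2)ccc1=O` gives 29.1% in a functional assay on the whole organism with Rattus norvegicus as the target, at a dose of 100 mg/kg (a lower number here means less inhibition, a higher number more inhibition at the dose given (going by the name of the read-out)), the second highest of three numbers. Its nearest neighbour is compound 1 `N#CNC(=N)NCCCCCn1nc(-c2ccccc2)ccc1=O`, which in this assay gives 31%; the step of a number 1.9 percentage points lower from compound 1 to compound 3 (within the scatter) is within the scatter. Compound 2 `CC/N=C(\S)NCCCCCCn1nc(-c2ccccc2)ccc1=O` gives -5.6%, and the step of a number 34.7 percentage points higher from compound 2 to compound 3 (beyond the scatter) is large, as is a number 36.6 percentage points lower from compound 1 to compound 2 (beyond the scatter). Compound 4 `CN(C)/C(=N/CCCCCn1nc(-c2ccccc2)ccc1=O)NC#N` differs from compound 3 by a group of 8 heavy atoms (4 carbon, 4 nitrogen; no ring) in place of a group of 9 heavy atoms (5 carbon, 4 nitrogen; no ring), on a saturated chain carbon, five bonds along the chain from an aromatic nitrogen. The step that bears on this is a number 1.9 percentage points lower from compound 1 to compound 3 (within the scatter), a change in the same chain-end region that stayed within the scatter; the large steps involve compound 2, whose chain-end group is of another kind. No step beyond the scatter is therefore expected in this assay, a number 2.1 percentage points lower from compound 3 to compound 4 (within the scatter). Compound 4 is estimated at 27%, with a range from 12% to 42%.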

Compound 4, a percentage reported as inhibition, in the whole organism at one dose (the size of the read-out at that dose, not a potency): 63.9%
Compound 4: middle estimate off by 36.9 percentage points, on the low side, outside the stated range (above it).
By their numbers in this assay, from the lowest: compound 2; then compounds 3 and 1 (each within the scatter of the next); then compound 4.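

In this assay, the chain-end group on the saturated chain carbon, five bonds along the chain from an aromatic nitrogen, now shows large steps among nitrile-bearing groups: a number 34.8 percentage points higher from compound 3 to compound 4 (beyond the scatter) and a number 32.9 percentage points higher from compound 1 to compound 4 (beyond the scatter) stand beyond the scatter, although compound 1 and compound 3 lay within it. With a number 69.5 percentage points higher from compound 2 to compound 4 (beyond the scatter) as well, compound 4 stands clear of all three others. Nothing on hand accounts for this result.

Still open, as far as these compounds go, is how a longer chain carrying the group of compound 4, or a piperidine at the same chain end, would read in this assay.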